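The source may report more compounds than this note shows. Statements on the series, on what has been measured and on what is new or still open speak of the compounds shown alone.

In an in vitro assay on HEK-tsA201 cells for antagonist activity at Neuronal acetylcholine receptor; alpha4/beta2 (Homo sapiens), read by fluorescence and calcium flux (on this read-out lower numbers stand for stronger inhibition and higher numbers for weaker inhibition), three close relatives of the same amide core have been measured. Compound 1 `C=C(C)COc1ccc(C(=O)Nc2cccc(C)n2)cc1` gives 19600 nM. Compound 2 `CCOc1ccc(C(=O)Nc2cc(C)cc(C)n2)cc1` gives 17100 nM. Compound 3 `CCCOc1ccc(C(=O)Nc2cccc(Br)n2)cc1` gives 80700 nM, the highest number of the three: both compound 1 and compound 2 sit below it by margins that go beyond the scatter of repeated measurements, so within this small set compound 3 is the weakest inhibitor.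

From compound 3 the account moves to compound 4 `CCCOc1ccc(C(=O)Nc2cccc(Nc3ccccc3)n2)cc1`, which has not yet been measured in this assay. The change is anilino in place of bromo on an aromatic carbon. Among the measured compounds shown here, no measured pair in the set isolates this kind of exchange, so there is no directly comparable step to lean on; what is known is only that all three measured numbers lie in a weak range.

The expectation is that compound 4 will sit somewhat lower than compound 3, with a step of a 2.0-fold lower number from compound 3 to compound 4 (0.30 log units; within the scatter), an estimate rather than a measurement. Compound 4 is therefore expected to give about 40000 nM, with a plausible range from 10000 nM to 150000 nM.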

Compound 4, half-maximal inhibitory concentration: > 100000 nM
Compound 4 ended at the assay's limit (the forecaster's own chance of this, stated with the estimate: 30%); at least 2.5-fold (0.39 log units) between middle value and limit.
By their numbers in this assay, from the lowest: compounds 2 and 1 (each within the scatter of the next); then compound 3. At a limit, above all of these: compound 4.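

In this assay compound 4 gives > 100000 nM, which is a limit of the assay and not a number. Anilino in place of bromo on this carbon next to the ring nitrogen gives an at least 1.2-fold higher number from compound 3 to compound 4 (0.09 log units; that floor lies within the scatter), so bringing a whole aromatic ring and a hydrogen-bond donor to this position yields no gain in inhibition, although the floor of the step alone does not establish a loss. The reading of this exchange stops at the edge of what the assay can report: the limit of > 100000 nM in this assay, at which 1 of the 4 values shown sits.

Going by these compounds, how far compound 4 lies past that limit remains open, and with it the true size of the step. Also open, on these data alone, is whether a small amine such as methylamino, or a saturated ring amine such as morpholine, on the same carbon would keep, lower or raise the number seen with bromo.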